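One Methyl Less: From Compound 2 to Compound 3

This account rests on a few compounds, and the source may have more. Where it says the series, first, only, none or still open, it means among the compounds named here.

Of the compounds shown here, two have been tested in a functional assay on MDA-MB-435 cells (Homo sapiens) for cytotoxicity, read by sulforhodamine B assay, with a stated time of 48 h, tested at 100 nM; a lower number here means a stronger effect, a higher number a weaker effect of the compound at the concentration tested. Compound 1 `Cc1cc(O)cc(-c2nn(CC#N)cc2-c2ccnc(-c3ccc(Oc4ccccc4)cc3)c2)c1` gives 89% in this assay. Compound 2 `COc1cc(C)cc(-c2nn(CC#N)cc2-c2ccnc(-c3ccc(N(C)C)cc3)c2)c1` gives -25% in this assay and stands lowest of the two numbers; its nearest neighbour is compound 1, whose number lies higher by a margin beyond the usual scatter. Compound 3 `Cc1cc(O)cc(-c2nn(CC#N)cc2-c2ccnc(-c3ccc(N(C)C)cc3)c2)c1` has not yet been measured. It differs from compound 2 in one place: hydrogen in place of methyl on an oxygen on an aromatic ring, that is, methoxy to hydroxy on the 3-methoxy-5-methylphenyl ring, which becomes 3-hydroxy-5-methylphenyl. Among the measured compounds shown here, no pair of measured compounds isolates this change, since compound 1 and compound 2 differ in two places at once, so its weight cannot be read from the data. The step from compound 2 to compound 3 is expected to be modest and to point toward a weaker effect, a number 35 percentage points higher from compound 2 to compound 3 (beyond the scatter), with wide uncertainty. For compound 3 the expected value in this assay is 10%, within a range from -30% to 70%.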

Compound 3, a percentage reported as activity, at one concentration (the size of the read-out at that concentration, not a potency): 51%
Compound 3: the middle estimate sits 41 percentage points below what was measured, within the range that was stated.
By their numbers in this assay, from the lowest: compound 2; then compound 3; then compound 1.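

Hydrogen in place of methyl on an oxygen on an aromatic ring gives a number 76 percentage points higher from compound 2 to compound 3 (beyond the scatter) in this assay, so the methoxy to hydroxy change, which no earlier pair isolated, carries a large weight on its own and leads to a weaker effect. With the hydroxy held constant, dimethylamino in place of phenoxy gives a number 38 percentage points lower from compound 1 to compound 3 (beyond the scatter), so the wide gap between compound 1 and compound 2 now resolves into two single changes, each large and each beyond the scatter. Nothing at hand explains why either change has such weight.

On these data alone, whether a longer chain on this oxygen, such as ethoxy, would keep the effect of methoxy remains open. So does the outcome of placing an amine or a carboxylic acid on the ring at this oxygen's place.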